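A few compounds are considered here, and "the series" means these few. Any claim that something is new, unique, unknown or untested is made for them only; others in the source may bear on it.

In a functional assay on MDA-MB-231 cells (Homo sapiens) for inhibition, read by MTT assay, with a stated time of 72 h (a higher number here means a weaker inhibitor, a lower number a stronger inhibitor), compound 2 `CC[C@@H](C)[C@H](NC(=O)c1cc(Cl)ccc1OCCNC(=O)OC(C)(C)C)C(=O)Nc1ccc([N+](=O)[O-])cc1Cl` gives 4020 nM. Among the compounds with values here, compound 3 `CC[C@@H](C)[C@H](NC(=O)c1cc(Cl)ccc1OCCN)C(=O)Nc1ccc([N+](=O)[O-])cc1Cl` gives 6180 nM, and with a 1.5-fold higher number from compound 2 to compound 3 (0.19 log units; within the scatter) the only two numbers stand level. Compound 1 `CC(C)C[C@H](NC(=O)c1cc(Cl)ccc1OCCNC(=O)OC(C)(C)C)C(=O)Nc1ccc([N+](=O)[O-])cc1Cl` reaches only a limit, > 10000 nM. Compound 4 `CC(C)(C)OC(=O)CC[C@H](NC(=O)c1cc(Cl)ccc1OCCNC(=O)OC(C)(C)C)C(=O)Nc1ccc([N+](=O)[O-])cc1Cl` differs from compound 2 at one place: 2-(tert-butoxycarbonyl)ethyl in place of sec-butyl on a saturated chain carbon bound to an amide-type nitrogen and a carbonyl carbon. That step removes the amine protecting group elsewhere and so bears little here. The relevant precedent is the change on the same carbon, an at least 2.4-fold lower number from compound 1 to compound 2 (0.39 log units; beyond the scatter), which rests on the limit in the limit of > 10000 nM in this assay, at which 1 of the 3 values shown sits, and shows that this carbon can shift the number. A move upward is therefore expected, estimated as a 1.7-fold higher number from compound 2 to compound 4 (0.24 log units; within the scatter). For compound 4 the expected value is 7000 nM, with an estimated range of 2500 nM to 20000 nM.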

Compound 4, half-maximal inhibitory concentration: > 10000 nM
Compound 4 gave a limit, no number; the forecaster's own chance of this, stated with the estimate: 35%; at least 1.4-fold (0.15 log units) between middle value and limit.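

At the saturated chain carbon bound to an amide-type nitrogen and a carbonyl carbon, 2-(tert-butoxycarbonyl)ethyl in place of sec-butyl gives an at least 2.4-fold higher number from compound 2 to compound 4 (0.39 log units; beyond the scatter), so sec-butyl now holds the lower number in this assay against two other groups. Compound 4 gives a limit, > 10000 nM, not a number. The step between the two limited compounds cannot be read, so those two groups stay unranked: the limit of > 10000 nM in this assay, at which 2 of the 4 values shown sit.

Going by these compounds, whether a carboxylic acid in place of the tert-butyl ester on this chain would give a readable number stays open. So does the effect of a shorter branched chain, such as isopropyl, at this carbon.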